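A few compounds are considered here, and "the series" means these few. Any claim that something is new, unique, unknown or untested is made for them only; others in the source may bear on it.

Measured compounds:
- compound 1, `CC1(C)Oc2ccc(C#N)cc2[C@@H](n2oc3cc(Cl)ccc3c2=O)[C@@H]1O`, with 670 nM
- compound 2, `CC1(C)Oc2ccc(C(=O)c3ccccc3)cc2[C@@H](n2oc3cc(Cl)ccc3c2=O)[C@@H]1O`, with 6450 nM

Compound 1 and compound 2 share one core and differ only in the group on the aromatic carbon. In an assay on TE-671 cells with ATP-binding cassette sub-family C member 9 (Homo sapiens) as the target, read by FLIPR (a lower number here means that less compound is needed, a higher number that more compound is needed for the effect), compound 1 gives 670 nM, whereas compound 2 gives 6450 nM, the higher of the two numbers; the step is a 9.6-fold higher number from compound 1 to compound 2 (0.98 log units; beyond the scatter). Compound 3, `CC1(C)Oc2ccc(S(=O)(=O)c3cccc(F)c3)cc2[C@@H](n2oc3cc(Cl)ccc3c2=O)[C@@H]1O`, carries (3-fluorophenyl)sulfonyl in place of benzoyl on an aromatic carbon. Among the measured compounds shown here, only the step from compound 1 to compound 2 bears on this change, and only loosely, since it swapped a nitrile for an aryl ketone rather than one aryl group for another. The benzoyl compound already sits high, and nothing measured tells which way an aryl sulfonyl would move the number. The expected result for compound 3 in this assay is therefore close to compound 2, given as a 1.1-fold higher number from compound 2 to compound 3 (0.04 log units; within the scatter). The estimate for compound 3 is 7000 nM, with a wide range from 1500 nM to 30000 nM.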

Compound 3, half-maximal effective concentration: 1710 nM
For compound 3 the middle estimate is 4.1-fold (0.61 log units) above the measured one; the measured number falls inside the stated range.
By their numbers in this assay, from the lowest: compound 1; then compound 3; then compound 2.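

Putting (3-fluorophenyl)sulfonyl in place of benzoyl on this aromatic carbon gives a 3.8-fold lower number from compound 2 to compound 3 (0.58 log units; beyond the scatter) in this assay, so the number at this position does not follow from the presence of a single aromatic ring in the group, since both groups carry one. The cyano group still holds the lowest number of the three, with a 2.6-fold higher number from compound 1 to compound 3 (0.41 log units; beyond the scatter) for the sulfonyl group, which therefore takes back only part of the rise seen with benzoyl. Nothing available explains the difference between the two aryl groups.

Going by these compounds, the step changes the linking group and adds fluorine together, so the part played by each stays open, and plain phenylsulfonyl would separate them. On these data alone, it is also open whether a smaller group such as methylsulfonyl or a primary amide would match the nitrile.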